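Adding a methoxy group on the carbonyl-side ring of compound 3

A few compounds are considered here, and "the series" means these few. Any claim that something is new, unique, unknown or untested is made for them only; others in the source may bear on it.

All numbers come from a functional assay on IGROV-1 cells (Homo sapiens) for inhibition, read by sulforhodamine B assay, with a stated time of 48 h; on this read-out higher numbers stand for lower toxicity in this test and lower numbers for higher toxicity in this test. Compound 1 `COc1cc(-c2cc(/C=C/C(=O)c3ccc(Cl)c(Cl)c3)[nH]n2)cc(OC)c1OC` gives > 100000 nM, which is a limit of the assay and not a number (the limit of > 100000 nM in this assay, at which 1 of the 3 values shown sits). Compound 2 `COc1ccc(-c2cc(/C=C/C(=O)c3cc(OC)c(OC)c(OC)c3)[nH]n2)cc1OC` gives 46700 nM. Compound 3 `COc1ccc(C(=O)/C=C/c2cc(-c3cc(OC)c(OC)c(OC)c3)n[nH]2)cc1OC` gives 6480 nM, the lowest of the two numbers shown; the nearest number, that of compound 2, sits higher by a gap beyond the scatter. Going by the values given here, the only step between compounds that differ in one place is an at least 15-fold lower number from compound 1 to compound 3 (1.18 log units; beyond the scatter), a large move.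

Compound 4 `COc1cc(C(=O)/C=C/c2cc(-c3cc(OC)c(OC)c(OC)c3)n[nH]2)cc(OC)c1OC` differs from compound 3 by methoxy in place of hydrogen on an aromatic carbon. Among the compounds with values here, no measured step concerns this exchange: the step from compound 1 to compound 3 swaps a whole substituted phenyl on the carbonyl carbon and says nothing about a single added methoxy. Compound 2 carries the same three-methoxy pattern on the carbonyl side but differs from compound 3 in more than one place, so the gap between them cannot be assigned to the methoxy alone. With nothing bearing directly on the change, a step within the scatter is expected, in no set direction. The expected step is a 1.2-fold higher number from compound 3 to compound 4 (0.09 log units; within the scatter). Compound 4 is therefore estimated at 8000 nM, within 2500 nM to 25000 nM.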

Compound 4, concentration lethal to 50% of the cells: 33100 nM
Estimate against measurement, compound 4: 4.1-fold (0.62 log units) below; measured number outside the range, above it.
By their numbers in this assay, from the lowest: compound 3; then compounds 4 and 2 (each within the scatter of the next). At a limit, above all of these: compound 1.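

On the carbonyl-side ring of compound 3, a methoxy ortho to a methoxy group and meta to a large group is not a silent addition: this assay gives a 5.1-fold higher number from compound 3 to compound 4 (0.71 log units; beyond the scatter) and so moves toward lower toxicity in this test. The same exchange of methoxy in place of hydrogen, made on the other aromatic ring, gives a 1.4-fold lower number from compound 2 to compound 4 (0.15 log units; within the scatter) and stays within the scatter, so in these two pairs the outcome depends on which ring carries the new methoxy. Nothing at hand gives a reason for the step on the carbonyl-side ring.

From the compounds shown here alone, whether this step belongs to the methoxy itself or would follow any group at that place stays open, as a hydroxy group, a fluorine or an amine there would have to show. Going by these compounds, with a single pair on each ring and a single cell read-out, it also stays open whether the contrast between the two rings holds for other substituents or in other cells.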